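The source may report more compounds than this note shows. Statements on the series, on what has been measured and on what is new or still open speak of the compounds shown alone.

In a toxicity assay on HEK-293T cells (Homo sapiens) for cytotoxicity, read by MTT assay, with a stated time of 72 h (on this read-out higher numbers stand for weaker inhibition and lower numbers for stronger inhibition), compound 1 (`O=C1c2c[n+]([O-])c3ccccc3c2C(=O)c2c1c1ccccc1n2Cc1cn(C[C@H](O)CO)nn1`) gives 8880 nM and compound 2 (`CN1CCN(CCCCn2c3c(c4ccccc42)C(=O)c2c[n+]([O-])c4ccccc4c2C3=O)CC1`) gives 100 nM as the lower of the two numbers. Compound 3 (`O=C1c2c[n+]([O-])c3ccccc3c2C(=O)c2c1c1ccccc1n2CCCCN1CCNCC1`) differs from compound 2 by one edit (hydrogen in place of methyl on an amine nitrogen in a ring) with hydrogen in place of methyl on an amine nitrogen in a ring. Going by the values given here, the only measured step (an 89-fold lower number from compound 1 to compound 2 (1.95 log units; beyond the scatter)) exchanged a whole side group and says little about this smaller change, so no step beyond the scatter is expected in this assay. The estimated step (a 1.3-fold higher number from compound 2 to compound 3 (0.11 log units; within the scatter)) is accordingly small. For compound 3 the estimate is 130 nM with an expected range from 40 nM to 400 nM on this read-out.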

Compound 3, half-maximal inhibitory concentration: 760 nM
Compound 3: the middle estimate sits 5.8-fold (0.77 log units) below what was measured, and the stated range ends below it.
By their numbers in this assay, from the lowest: compound 2; then compound 3; then compound 1.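

In this assay, the amine nitrogen of the piperazine ring proves sensitive to a small edit: hydrogen in place of methyl gives a 7.6-fold higher number from compound 2 to compound 3 (0.88 log units; beyond the scatter), a step beyond the scatter from the loss of one carbon. Without that methyl, the side-group exchange still gives a 12-fold lower number from compound 1 to compound 3 (1.07 log units; beyond the scatter), so the piperazin-1-yl compound also keeps a lower number than the triazole compound. Nothing available here explains the effect of the methyl. From the compounds shown here alone, whether an ethyl, a 2-hydroxyethyl or an acetyl on this nitrogen would follow methyl or hydrogen remains open.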